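Amide-to-dimethylamino swap on the benzoyl group; single-point read

This account rests on a few compounds, and the source may have more. Where it says the series, first, only, none or still open, it means among the compounds named here.

Three compounds carry the shared core of compound 1 `COC(=O)c1cccc(C(=O)N2CCC(N(C3CC3)S(=O)(=O)c3cccc(C(F)(F)F)c3)CC2)c1` with varied benzoyl substituents. In an assay on cells for inhibition of Voltage-dependent L-type calcium channel subunit alpha-1C (Homo sapiens), read by FLIPR and calcium flux, tested at 3 uM (on this read-out higher numbers stand for a stronger effect at the one concentration tested and lower numbers for a weaker effect), compound 1 gives "not determined" (no result reported). Compound 3 `O=C(c1ccccc1OC(F)(F)F)N1CCC(N(C2CC2)S(=O)(=O)c2cccc(C(F)(F)F)c2)CC1` likewise gives "not determined" (no result reported) in this assay. Compound 2 `NC(=O)c1ccc(C(=O)N2CCC(N(C3CC3)S(=O)(=O)c3cccc(C(F)(F)F)c3)CC2)cc1` is the only member with a number: in this assay compound 2 gives 0%, with nothing else shown to place it against.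

Compound 4 `CN(C)c1cccc(C(=O)N2CCC(N(C3CC3)S(=O)(=O)c3cccc(C(F)(F)F)c3)CC2)c1` differs from compound 2 in one place: 3-(dimethylamino)phenyl in place of 4-carbamoylphenyl on a carbonyl carbon

Within the data shown here, no step between measured compounds exists to calibrate this change. Compound 2 shows no inhibition in this assay, so a drop is not possible, and the expected step from compound 2 to compound 4 is small, within the usual scatter or slightly upward, a number 8 percentage points higher from compound 2 to compound 4 (within the scatter). Compound 4 is estimated at 8%, in the range 0% to 30%.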

Compound 4, a percentage reported as inhibition, at one concentration (the size of the read-out at that concentration, not a potency): 63%
Compound 4: middle estimate off by 55 percentage points, on the low side, outside the stated range (above it).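

In this assay, the group on the carbonyl carbon proves able to move this read-out: 3-(dimethylamino)phenyl in place of 4-carbamoylphenyl gives a number 63 percentage points higher from compound 2 to compound 4 (beyond the scatter). Compound 2 alone could not show that this place responds to change at all. The swap alters both the substituent and its ring position, so the step cannot be assigned to either, and no measured property bears on its cause.

Open, from the compounds shown here alone, is whether 4-(dimethylamino)phenyl or 3-carbamoylphenyl would separate those two changes. Also open, going by these compounds, is whether a primary amine or a pyrrolidine would serve in place of the dimethylamino group.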